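The source may report more compounds than this note shows. Statements on the series, on what has been measured and on what is new or still open speak of the compounds shown alone.

Compound 1 `Fc1cccc(Cn2ccc3nc(-c4ccccc4)nc-3c2)c1`: > 100000 nM
Compound 2 `c1ccc(-c2nc3ccn(Cc4cccc5ccccc45)cc-3n2)cc1`: 61000 nM
Compound 3 `c1ccc(-c2nc3ccn(Cc4ccc5ccccc5c4)cc-3n2)cc1`: 67000 nM

Of the compounds shown here, three sharing one core have been measured in an ADME assay on MDBK cells (Bos taurus) for cytotoxicity; a lower number here means that less compound is tolerated, a higher number that more compound is tolerated. In this assay compound 2 gives 61000 nM and compound 3 gives 67000 nM, two readings that sit within the usual scatter of each other. Compound 1 stands apart only in the kind of result: its reading is a limit of the assay and not a number, namely (the limit of > 100000 nM in this assay, at which 1 of the 3 values shown sits), so for compound 1 only a bound is known. Among the measured compounds shown here, none of the three differs from another in a single place, so no measured step is available.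

Compound 4 `c1ccc(-c2nc3ccn(Cc4ccccn4)cc-3n2)cc1` has not yet been measured. It differs from compound 1 in one place: pyridin-2-yl in place of 3-fluorophenyl on a saturated chain carbon bound to an aromatic nitrogen. For the measured compounds named here, nothing among the measured compounds speaks to this exchange, and all three readings cluster near the top of the range. The step from compound 1 to compound 4 is therefore expected to be none beyond the scatter, as a number no higher from compound 1 to compound 4 (the limit leaves the size open). For compound 4 the estimate in this assay is 100000 nM, expected between 50000 nM and 200000 nM, with a fair chance that again only a limit is reported.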

Compound 4, half-maximal cytotoxic concentration: > 100000 nM
Compound 4 was reported as a limit; the forecaster's own chance of this, stated with the estimate: 55%; the middle value lies on the limit itself.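

In this assay compound 4 gives > 100000 nM as a limit of the assay and not a number. Among the compounds shown here, compound 1 and compound 4 both rest on a limit, so no step between them can be read: the limit of > 100000 nM in this assay, at which 2 of the 4 values shown sit. The compounds shown leave open whether pyridin-2-yl and 3-fluorophenyl differ at all in this assay.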